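Chloro to methyl on the aryl ring of compound 1

The compounds below may be only part of what the source reports. "The series", "measured", "known", "first", "only" and "open" are said of these compounds alone.

Measured compounds in a functional assay on A549 cells (Homo sapiens) for antiproliferative activity, read by MTT assay, with a stated time of 72 h; a lower number here means a stronger inhibitor, a higher number a weaker inhibitor:
compound 1 `NC1=NC2(CCOCC2)N(OCCCOc2ccc(Cl)cc2)C(N)=N1` gives 360 nM
compound 2 `NC1=NC2(CCSCC2)N(OCCCOc2ccccc2Cl)C(N)=N1` gives 80 nM
compound 3 `NC1=NC2(CCOCC2)N(OCCCOc2cccc(Cl)c2)C(N)=N1` gives 150 nM

Compound 1 has the highest number of the three. Compound 3, with 3-chlorophenyl in place of 4-chlorophenyl on an oxygen on a saturated carbon, gives a 2.4-fold lower number from compound 1 to compound 3 (0.38 log units; beyond the scatter). Compound 2 differs from compound 1 in two places at once, so only its lower value is on record, not a single step.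

Compound 4 `Cc1ccc(OCCCON2C(N)=NC(N)=NC23CCOCC3)cc1` carries methyl in place of chloro on an aromatic carbon. Within the data shown here, no measured pair swaps chloro for methyl; the one known step only moves the chloro around the ring. The new compound is therefore expected to sit near compound 1, and the estimated step of a 1.1-fold higher number from compound 1 to compound 4 (0.05 log units; within the scatter) is within the scatter. Compound 4 is expected to give about 400 nM, from 150 nM to 1100 nM.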

Compound 4, half-maximal inhibitory concentration: 1060 nM
For compound 4 the middle estimate is 2.7-fold (0.42 log units) below the measured one; the measured number falls inside the stated range.
By their numbers in this assay, from the lowest: compounds 2 and 3 (each within the scatter of the next); then compound 1; then compound 4.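

In this assay the 4-methylphenyl group does not stand in for 4-chlorophenyl: the swap gives a 2.9-fold higher number from compound 1 to compound 4 (0.47 log units; beyond the scatter) and shows that this place responds to the group itself, not only to where the chloro sits. Against 3-chlorophenyl, the gap grows to a 7.1-fold higher number from compound 3 to compound 4 (0.85 log units; beyond the scatter) in the same direction. No evidence at hand bears on this result. Still open, on these data alone, is whether fluoro, methoxy or nitrile on this aromatic carbon would track chloro or methyl, and whether a longer chain would change the step.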